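Working notes: changing the amide nitrogen substituent

A few compounds are considered here, and "the series" means these few. Any claim that something is new, unique, unknown or untested is made for them only; others in the source may bear on it.

Measured in a functional assay on THP-1 cells (Homo sapiens) for cytotoxicity, read by MTT assay, with a stated time of 24 h; on this read-out lower numbers stand for stronger inhibition and higher numbers for weaker inhibition:
- compound 1 `Nc1nn(Cc2cn(CC(=O)Nc3ccccc3)nn2)c2nc(-c3ccccc3)cc(C(F)(F)F)c12`: 54.6 ug/mL
- compound 2 `Nc1nn(Cc2cn(CC(=O)Nc3c(F)cccc3F)nn2)c2nc(-c3ccccc3)cc(C(F)(F)F)c12`: 43.3 ug/mL

Compound 2 at 43.3 ug/mL cannot be told apart from compound 1 at 54.6 ug/mL. The next structure is compound 3 `Nc1nn(Cc2cn(CC(=O)NC3CCCCC3)nn2)c2nc(-c3ccccc3)cc(C(F)(F)F)c12`, which differs from compound 2 as follows: cyclohexyl in place of 2,6-difluorophenyl on an amide-type nitrogen. Among the compounds with values here, the single measured step, a 1.3-fold lower number from compound 1 to compound 2 (0.10 log units; within the scatter), stays within the scatter, but it only relates two aromatic substituents. Within the data shown here, no measured compound carries a non-aromatic ring at this place, so the expectation is loose. The expected change in this assay is a 1.2-fold higher number from compound 2 to compound 3 (0.06 log units; within the scatter), with no shift beyond the scatter anticipated. The estimate for compound 3 is 50 ug/mL, with an expected range of 22 ug/mL to 110 ug/mL.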

Compound 3, half-maximal inhibitory concentration: 64.8 ug/mL
Beside the measured number, compound 3's estimate is 1.3-fold (0.11 log units) below it; low and high end bracket the measured number.
By their numbers in this assay, from the lowest: compounds 2, 1 and 3 (each within the scatter of the next).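

In this assay cyclohexyl gives a 1.5-fold higher number from compound 2 to compound 3 (0.18 log units; within the scatter) when it replaces 2,6-difluorophenyl and a 1.2-fold higher number from compound 1 to compound 3 (0.07 log units; within the scatter) when it replaces phenyl on the amide-type nitrogen. The position therefore accepts a six-membered non-aromatic ring as well as the two aromatic rings, with no separation among the three compounds on this read-out. No measured evidence bears on this result.

Still open, going by these compounds, is whether a longer chain, or a ring carrying an amine or a carboxylic acid, on the amide-type nitrogen would move the number beyond the scatter.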